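Trimming a Sulfated Chain Down to a Phenyl Ring

The source may report more compounds than this note shows. Statements on the series, on what has been measured and on what is new or still open speak of the compounds shown alone.

Measured so far:
- compound 1, `CCN(CC(=O)NC[C@H]1O[C@H](OC)[C@@H](OS(=O)(=O)O)[C@@H](OS(=O)(=O)O)[C@@H]1OS(=O)(=O)O)C(=O)CCCCCCCCCOS(=O)(=O)O`: 240000 nM
- compound 2, `CO[C@H]1O[C@H](CNC(=O)CN(C(C)=O)C2CCCCC2)[C@@H](OS(=O)(=O)O)[C@H](OS(=O)(=O)O)[C@@H]1OS(=O)(=O)O`: 413000 nM

Both compounds were tested in an assay on isolated protein for binding affinity to fibroblast growth factor 2 (Homo sapiens), read by surface plasmon resonance; on this read-out higher numbers stand for weaker binding and lower numbers for tighter binding. Compound 1 gives 240000 nM, the lower of the two numbers, and compound 2 gives 413000 nM; the gap between them lies within the usual scatter, so the two cannot be ranked against each other. Both sit in a very weak range.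

Compound 3, `CCN(CC(=O)NC[C@H]1O[C@H](OC)[C@@H](OS(=O)(=O)O)[C@@H](OS(=O)(=O)O)[C@@H]1OS(=O)(=O)O)C(=O)CCCc1ccccc1`, has not yet been measured. Relative to compound 1 the change is phenyl in place of 6-(sulfooxy)hexyl on a saturated chain carbon, three bonds along the chain from a carbonyl carbon: a long sulfated tail on the side chain is swapped for a bare aromatic ring. Among the compounds with values here, with only two measured compounds and no recorded step between them, there is nothing to lean on except that both carry several sulfate groups and both bind weakly. Losing one more sulfate is expected to shift the number somewhat toward weaker binding, but the step from compound 1 to compound 3 is expected to be small, around a 1.7-fold higher number from compound 1 to compound 3 (0.22 log units; within the scatter), close to the scatter. Compound 3 is therefore estimated at 400000 nM, with a plausible range from 150000 nM to 1200000 nM.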

Compound 3, dissociation constant: 400000 nM
For compound 3 middle estimate and measured number coincide at the digits printed; the range from low to high includes it.
By their numbers in this assay, from the lowest: compounds 1, 3 and 2 (each within the scatter of the next).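

In this assay, putting phenyl in place of 6-(sulfooxy)hexyl on a saturated chain carbon, three bonds along the chain from a carbonyl carbon, gives a 1.7-fold higher number from compound 1 to compound 3 (0.22 log units; within the scatter), so the two groups cannot be told apart at this position. Within the data shown here, this is the first comparison here that isolates a single place, and it shows that a long tail ending in a sulfate and a bare aromatic ring give readings that the assay cannot separate, with both compounds still in the very weak range and the sulfates on the shared core unchanged. Nothing measured here explains why such different groups cannot be separated.

From the compounds shown here alone, it remains open whether a carboxylic acid or an amine at the end of the chain, or a sulfate on a much shorter chain, would give a reading clearly apart from these. Also open, going by these compounds, is whether a phenyl ring carrying its own sulfate would move the number beyond the scatter, which would show whether this position can influence binding at all.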